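Thiosemicarbazide pair: morpholinyl versus thiomorpholinyl, growth inhibition

The source may report more compounds than this note shows. Statements on the series, on what has been measured and on what is new or still open speak of the compounds shown alone.

Measured compounds:
- compound 1, `Cc1ccnc(/C(N)=N/NC(=S)N2CCOCC2)c1`: 82.8%
- compound 2, `Cc1ccnc(/C(N)=N/NC(=S)N2CCSCC2)c1`: 79.6%
- compound 3, `N/C(=N\NC(=S)N1CCSCC1)c1ccc(F)cn1`: 86.6%

The read-out is a functional assay on A-431 cells (Homo sapiens) for cytotoxicity, read by MTT assay, with a stated time of 72 h, tested at 100 uM; on this read-out lower numbers stand for less inhibition of growth and higher numbers for more inhibition of growth at the one concentration tested. Compound 1 gives 82.8%, compound 2 gives 79.6% and compound 3 gives 86.6%. All three numbers lie close together; the difference between compound 3 and the other two is within the usual scatter, so no order among them can be read.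

Compound 1 and compound 2 share a core and differ by one change, (morpholin-4-yl in place of thiomorpholin-4-yl on a thiocarbonyl carbon). The step is a number 3.2 percentage points higher from compound 2 to compound 1 (within the scatter). Compound 3 carries a different core; the difference between the cores of compound 2 and compound 3 is not broken down here.

Compound 4, `N/C(=N\NC(=S)N1CCOCC1)c1ccc(F)cn1`, has not been measured in this assay . It is related to compound 3 by morpholin-4-yl in place of thiomorpholin-4-yl on a thiocarbonyl carbon, the same change, at the same place, as that from compound 2 to compound 1.

Expectation: since the same exchange within the first pair gave only a number 3.2 percentage points higher from compound 2 to compound 1 (within the scatter), compound 4 is expected to sit near compound 3 in this assay , with an estimated step of a number 1.4 percentage points higher from compound 3 to compound 4 (within the scatter). The estimate for compound 4 in this assay is 88%, with a likely span from 79% to 95%. This rests on two compounds only, and the measurement of compound 4 will show whether it holds.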

Compound 4, percent growth inhibition at one concentration: 85.6%
The estimate for compound 4 lay 2.4 percentage points above the measured number; measured number inside the range.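

In this assay, the exchange of thiomorpholin-4-yl for morpholin-4-yl on a thiocarbonyl carbon gives, on the second core, a number 1 percentage points lower from compound 3 to compound 4 (within the scatter). Set beside the first pair, the change shows no readable difference in its size between the two cores: the same change on two cores in this assay, a number 3.2 percentage points higher (within the scatter) from compound 2 to compound 1 and a number 1 percentage points lower (within the scatter) from compound 3 to compound 4, 4.2 percentage points apart, within the scatter of two such steps. This supports only a limited statement: on these two cores the exchange leaves the read-out within the scatter, and neither step has a direction that can be read, while two cores at one tested concentration do not show that the exchange would behave the same way at lower concentrations or on further cores.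

The compounds shown cover only two closely matched rings on the thiocarbonyl carbon, so it remains open whether a piperidin-1-yl ring, a 4-methylpiperazin-1-yl ring with its additional amine, or an open-chain dimethylamino group would stay within the same narrow band in this assay. Also open, on these data alone, is whether the four compounds would separate in a concentration series, and what the difference between the two cores contributes on its own.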